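The compounds below may be only part of what the source reports. "The series", "measured", "known", "first", "only" and "open" are said of these compounds alone.

Measured so far in a functional assay on HL-60 cells (Homo sapiens) for antiproliferative activity, with a stated time of 24 h; a higher number here means a weaker inhibitor, a lower number a stronger inhibitor:
- compound 1 `NC(=O)c1c(NC(=O)c2ccccc2Cl)sc2c1CCN(C(=S)Nc1ccccc1C(F)(F)F)C2` gives 10600 nM
- compound 2 `NC(=O)c1c(NC(=O)c2ccccc2Cl)sc2c1CCN(C(=S)Nc1cccnc1)C2` gives 33900 nM

Compound 1 holds the lower number of the two. Compound 3 `NC(=O)c1c(NC(=O)c2ccccc2Br)sc2c1CCN(C(=S)Nc1ccccc1C(F)(F)F)C2` keeps the rest of compound 1 and differs by bromo in place of chloro on an aromatic carbon, ortho to a large group. Within the data shown here, the only measured step, a 3.2-fold higher number from compound 1 to compound 2 (0.50 log units; beyond the scatter), is modest and lies on an amide-type nitrogen, so it bears only indirectly. Among the measured compounds shown here, no measured step covers this halogen swap, so no step beyond the scatter is expected in this assay. The expected step is a 1.1-fold lower number from compound 1 to compound 3 (0.03 log units; within the scatter), within the scatter. Compound 3 is expected at 10000 nM, with an estimated range of 5000 nM to 20000 nM.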

Compound 3, half-maximal inhibitory concentration: 27400 nM
For compound 3 the middle estimate is 2.7-fold (0.44 log units) below the measured one, outside the stated range (above it).
By their numbers in this assay, from the lowest: compound 1; then compounds 3 and 2 (each within the scatter of the next).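

In this assay, bromo in place of chloro gives a 2.6-fold higher number from compound 1 to compound 3 (0.41 log units; beyond the scatter) and so this aromatic carbon, ortho to a large group, responds to the exchange of a single halogen atom. The earlier pair showed a change only on the amide-type nitrogen, whereas this step places a second sensitive point on the other side of the shared core. Nothing measured here accounts for the size of this step.

On these data alone, whether fluoro, methyl or methoxy at this carbon would match chloro remains open. Also open, as far as these compounds go, is whether the same halogen exchange gives a similar step when pyridin-3-yl sits on the amide-type nitrogen.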